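Swapping the ring on compound 3 for a dimethylmorpholine

This account rests on a few compounds, and the source may have more. Where it says the series, first, only, none or still open, it means among the compounds named here.

Compound 3 `N#Cc1cccc(-c2nc(N)c3cc(CN4CC=CCC4)sc3n2)c1` shares its core with compound 1 `Nc1nc(-c2ccco2)nc2sc(CN3CC=CCC3)cc12` and compound 2 `C[C@@H]1CCC[C@H](C)N1Cc1cc2c(N)nc(-c3cccc(C#N)c3)nc2s1`. In an assay on CHO-K1 cells for antagonist activity at adenosine receptor A1 (Homo sapiens), read by a beta-galactosidase reporter, with stated times of 15 min and 6 h (a lower number here means a stronger inhibitor, a higher number a weaker inhibitor), compound 3 gives 210 nM, the second highest of the three numbers; compound 1 gives 150 nM and compound 2 gives 460 nM. The step of a 1.4-fold higher number from compound 1 to compound 3 (0.15 log units; within the scatter) lies within the scatter. The step of a 2.2-fold lower number from compound 2 to compound 3 (0.34 log units; beyond the scatter) shows that changing the ring on the saturated chain carbon bound to an aromatic carbon can shift the number modestly. Compound 4 `C[C@@H]1CN(Cc2cc3c(N)nc(-c4cccc(C#N)c4)nc3s2)C[C@H](C)O1` carries a group of 8 heavy atoms (6 carbon, 1 nitrogen, 1 oxygen; one six-membered non-aromatic ring with 2 hetero atoms) in place of a group of 6 heavy atoms (5 carbon, 1 nitrogen; one six-membered non-aromatic ring with 1 hetero atom), on a saturated chain carbon bound to an aromatic carbon. Because this change sits at the same place as a 2.2-fold lower number from compound 2 to compound 3 (0.34 log units; beyond the scatter), a modest rise in the number is expected, a 2.4-fold higher number from compound 3 to compound 4 (0.38 log units; beyond the scatter). Compound 4 is therefore expected to give about 500 nM, between 200 nM and 1500 nM.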

Compound 4, inhibition constant: 1070 nM
Estimate against measurement, compound 4: 2.1-fold (0.33 log units) below, within the range that was stated.
By their numbers in this assay, from the lowest: compounds 1 and 3 (each within the scatter of the next); then compound 2; then compound 4.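

In this assay, the step of a 5.1-fold higher number from compound 3 to compound 4 (0.71 log units; beyond the scatter) is the largest shift yet seen on this saturated chain carbon bound to an aromatic carbon. The ring change matters even between two dimethyl rings: 2,6-dimethylmorpholin-4-yl in place of 2,6-dimethylpiperidin-1-yl gives a 2.3-fold higher number from compound 2 to compound 4 (0.37 log units; beyond the scatter). No measurement shown explains either rise. The compounds shown leave open how much of the step from compound 3 comes from the ring oxygen and how much from the two methyl groups. A plain morpholin-4-yl on the same carbon would help separate them.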